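Compound 3 to compound 4: one group exchanged

This account rests on a few compounds, and the source may have more. Where it says the series, first, only, none or still open, it means among the compounds named here.

Measured in a functional assay on SiHa cells (Homo sapiens) for inhibition, read by sulforhodamine B assay; on this read-out lower numbers stand for stronger inhibition of growth and higher numbers for weaker inhibition of growth:
compound 1 `Oc1cccc2[nH]c(-c3ccc(-c4ccc(-c5ccc(C(F)(F)F)cc5)cc4)cc3)nc12`: 3720 nM
compound 2 `CN(C)c1ccc(-c2ccc(-c3ccc(-c4nc5c(O)cccc5[nH]4)cc3)cc2)cc1`: 6240 nM
compound 3 `Oc1cccc2[nH]c(-c3ccc(-c4ccc(-c5cccc(Cl)c5)cc4)cc3)nc12`: 8400 nM

Compound 3 gives 8400 nM, with a 1.3-fold higher number from compound 2 to compound 3 (0.13 log units; within the scatter) and a 2.3-fold higher number from compound 1 to compound 3 (0.35 log units; beyond the scatter). Compound 4 `COc1ccc(-c2ccc(-c3ccc(-c4nc5c(O)cccc5[nH]4)cc3)cc2)cc1OC` has not yet been measured and differs from compound 3 as follows: 3,4-dimethoxyphenyl in place of 3-chlorophenyl on an aromatic carbon. The new 3,4-dimethoxyphenyl stands on an aromatic carbon, para to a large group. The three measured exchanges at this place bear on it: besides the two above, there is a 1.7-fold higher number from compound 1 to compound 2 (0.22 log units; within the scatter). None of them is large, so only a small step is expected, with no change beyond the scatter in this assay. The estimated step is a 1.4-fold lower number from compound 3 to compound 4 (0.15 log units; within the scatter). For compound 4 the expected value is 6000 nM, with an estimated range of 2800 nM to 13000 nM.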

Compound 4, concentration for 50% growth inhibition: 1110 nM
For compound 4 the middle estimate is 5.4-fold (0.73 log units) above the measured one; the whole stated range lies above it.
By their numbers in this assay, from the lowest: compound 4; then compounds 1, 2 and 3 (each within the scatter of the next, the first and the last beyond it).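

In this assay the steps of a 7.6-fold lower number from compound 3 to compound 4 (0.88 log units; beyond the scatter) and a 5.6-fold lower number from compound 2 to compound 4 (0.75 log units; beyond the scatter) and a 3.4-fold lower number from compound 1 to compound 4 (0.53 log units; beyond the scatter) all lie beyond the scatter, so 3,4-dimethoxyphenyl gives the lowest number of the four groups at this place. The number at this place thus depends on the group more strongly than the spread among compound 1, compound 2 and compound 3 had shown. Nothing measured here accounts for this gap.

From the compounds shown here alone, whether a single methoxy group would give the same number stays open. So does whether a hydroxyl group or an amine on this outer ring would lower the number further.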